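The source may hold more compounds than are shown below. What is called first, only, known or untested is meant among the compounds shown, and "the series" means these compounds.

Measured so far:
- compound 1 `CCCCCCCCCCn1cc(-c2nc3ccccc3cc2C)nn1`: > 100 ug/mL
- compound 2 `Cc1cc2ccccc2nc1-c1cn(CCC(F)(F)C(F)(F)C(F)(F)C(F)(F)C(F)(F)C(F)(F)C(F)(F)C(F)(F)F)nn1`: 56.6 ug/mL

Both compounds were tested in a functional assay on U-937 cells (Homo sapiens) for cytotoxicity, read by MTT assay, with a stated time of 24 h; on this read-out higher numbers stand for weaker inhibition and lower numbers for stronger inhibition. For compound 1 the value > 100 ug/mL is a limit of the assay rather than a number, so compound 1 stands at the limit of > 100 ug/mL in this assay, at which 1 of the 2 values shown sits, and its true place among the numbers is not known beyond that. For the measured compounds named here, compound 2 gives a number, 56.6 ug/mL, but no step between compound 1 and compound 2 is counted here, so the two values are simply given as they stand, each for its own compound.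

Compound 3 `CCCCCCCCCCn1cc(-c2nc3ccccc3cc2CC)nn1` is the compound not yet measured. It differs from compound 1 by methyl in place of hydrogen on a saturated chain carbon bound to an aromatic carbon. Going by the values given here, with no measured step to lean on, the expected step that the limit leaves unreadable from compound 1 to compound 3 is small and within the scatter. The expected value for compound 3 is 150 ug/mL, within a range from 60 ug/mL to 400 ug/mL, and a limit again is likely.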

Compound 3, half-maximal inhibitory concentration: 12.7 ug/mL
Estimate against measurement, compound 3: 12-fold (1.07 log units) above; measured number outside the range, below it.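

In this assay, this position proves able to change the read-out: methyl in place of hydrogen on a saturated chain carbon bound to an aromatic carbon, which turns the methyl of compound 1 into an ethyl, gives an at least 7.8-fold lower number from compound 1 to compound 3 (0.89 log units; beyond the scatter). A change as small as this one, with the rest of the structure kept the same, is therefore enough to move the result beyond the usual scatter, towards stronger inhibition. The full size of the step cannot be stated, since the value of compound 1 is a limit and not a number: the limit of > 100 ug/mL in this assay, at which 1 of the 3 values shown sits.

Going by these compounds, whether a longer chain such as propyl, or an amine or a carboxylic acid, would be tolerated at this place remains open. So does whether the change from methyl to ethyl would act in the same way on compound 2, which carries a different chain.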